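The source may hold more compounds than are shown below. What is called first, only, known or untested is meant among the compounds shown, and "the series" means these compounds.

Measured in a functional assay on PANC-1 cells (Homo sapiens), read by microscopy, crystal violet staining and transwell migration, with a stated time of 18 h, in the presence of a further agent that is not named here; on this read-out higher numbers stand for weaker inhibition and lower numbers for stronger inhibition:
- compound 1 `CCCCc1nc(-c2ccc(OC)cc2)n(-c2cccc(C(=O)NCCCCc3ccccc3)c2)n1`: 16800 nM
- compound 2 `CCc1nc(-c2ccc(OC(F)F)cc2)n(-c2cccc(C(=O)NCCCCc3ccccc3)c2)n1`: 830 nM
- compound 3 `CCc1nc(-c2ccc(OC)nc2)n(-c2cccc(C(=O)NCCCCc3ccccc3)c2)n1`: 810 nM

Compound 3 stands level with compound 2, the two lying within the scatter of each other. Compound 1 gives a number beyond the scatter higher than either, but it differs from compound 3 in more than one place, so its value cannot be tied to any single change.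

The next compound to be tested is compound 4 `CCc1nc(-c2ccc(O)cc2)n(-c2cccc(C(=O)NCCCCc3ccccc3)c2)n1`. It carries 4-hydroxyphenyl in place of 6-methoxypyridin-3-yl on an aromatic carbon of the shared core (4-hydroxyphenyl in place of 6-methoxypyridin-3-yl on an aromatic carbon).

For the measured compounds named here, only one measured step concerns this place, a 1.0-fold lower number from compound 2 to compound 3 (0.01 log units; within the scatter), and it exchanged 4-(difluoromethoxy)phenyl for 6-methoxypyridin-3-yl without a change beyond the scatter. Going by the values given here, no measured compound carries 4-hydroxyphenyl, so this single step is thin support. In this assay, no step beyond the scatter is therefore expected, with a slight lean towards a higher number and a wide margin on that side. The step expected is a 1.5-fold higher number from compound 3 to compound 4 (0.17 log units; within the scatter). For compound 4 the estimate is 1200 nM, with an expected range from 350 nM to 5000 nM.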

Compound 4, half-maximal inhibitory concentration: 220 nM
Compound 4: middle estimate off by 5.5-fold (0.74 log units), on the high side; measured number outside the range, below it.
By their numbers in this assay, from the lowest: compound 4; then compounds 3 and 2 (each within the scatter of the next); then compound 1.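

In this assay, for the compounds shown here, the group on this aromatic carbon proves able to move the number, which the earlier compounds did not show: the exchange between compound 2 and compound 3 stayed within the scatter, whereas 4-hydroxyphenyl in place of 6-methoxypyridin-3-yl gives a 3.7-fold lower number from compound 3 to compound 4 (0.57 log units; beyond the scatter), a modest step. Going by these compounds alone, the single change at the oxygen, hydrogen in place of difluoromethyl, gives a 3.8-fold lower number from compound 2 to compound 4 (0.58 log units; beyond the scatter), so among the three compounds that share the ethyl group, only the one with a free hydroxyl and its hydrogen-bond donor stands apart, and neither of the other two goes against this. Nothing at hand gives a reason for this difference.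

Whether the hydrogen of the hydroxyl is what counts stays open, since the compounds shown do not tell how an amine, a primary carboxamide or a carboxylic acid in its place on the phenyl ring would compare. As far as these compounds go, it also stays open how this hydroxyl would fare with a longer chain such as the butyl group of compound 1, whose value comes with a second difference and cannot be tied to either one.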